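Trifluoromethyl for methylsulfonyl on the benzyl group

The source may report more compounds than this note shows. Statements on the series, on what has been measured and on what is new or still open speak of the compounds shown alone.

Values in an assay on isolated protein for displacement of a labelled ligand from Apoptosis regulator Bcl-2 (Homo sapiens), read by fluorescence polarization (on this read-out higher numbers stand for weaker inhibition and lower numbers for stronger inhibition), so far:
compound 1 `CN(C)CC[C@H](CSc1ccccc1)Nc1ccc(S(=O)(=O)NC(=O)c2ccc(N3CCN(C(=O)Nc4ccccc4)CC3)cc2)cc1[N+](=O)[O-]` gives 300 nM
compound 2 `CN(C)CC[C@H](CSc1ccccc1)Nc1ccc(S(=O)(=O)NC(=O)c2ccc(N3CCN(Cc4ccccc4)CC3)cc2)cc1[N+](=O)[O-]` gives 39.8 nM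
compound 3 `CN(C)CC[C@H](CSc1ccccc1)Nc1ccc(S(=O)(=O)NC(=O)c2ccc(N3CCN(Cc4ccccc4S(C)(=O)=O)CC3)cc2)cc1[N+](=O)[O-]` gives 4.6 nM

Compound 3 holds the lowest number of the three in this assay; the two steps that lead to it are an 8.7-fold lower number from compound 2 to compound 3 (0.94 log units; beyond the scatter) and a 65-fold lower number from compound 1 to compound 3 (1.81 log units; beyond the scatter), both beyond the scatter.

Compound 4 `CN(C)CC[C@H](CSc1ccccc1)Nc1ccc(S(=O)(=O)NC(=O)c2ccc(N3CCN(Cc4ccccc4C(F)(F)F)CC3)cc2)cc1[N+](=O)[O-]` differs from compound 3 by trifluoromethyl in place of methylsulfonyl on an aromatic carbon. For the measured compounds named here, no measured pair covers this exact change. The step that bears on the same position is an 8.7-fold lower number from compound 2 to compound 3 (0.94 log units; beyond the scatter), which shows that putting methylsulfonyl onto the unsubstituted benzyl of compound 2 moved the number by a modest amount. Compound 4 keeps a group of the same heavy-atom count at that position but without the two hydrogen-bond acceptors that enter with methylsulfonyl, so the data leave open whether the gain seen from compound 2 to compound 3 is retained.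

The expectation is a number between those of compound 2 and compound 3, nearer compound 3: compound 4 is estimated at 12 nM in this assay, with a range of 4 nM to 40 nM, which corresponds to an expected step of a 2.6-fold higher number from compound 3 to compound 4 (0.42 log units; beyond the scatter).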

Compound 4, inhibition constant: < 1 nM
Compound 4: a limit, no number; the forecaster's own chance of this, stated with the estimate: 3%; middle value at least 12-fold (1.07 log units) from the limit.
By their numbers in this assay, from the lowest: compound 3; then compound 2; then compound 1. At a limit, below all of these: compound 4.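

In this assay, compound 4 gives a limit and not a number: the limit of < 1 nM in this assay, at which 1 of the 4 values shown sits.

At this aromatic carbon, the two hydrogen-bond acceptors that leave with methylsulfonyl turn out not to be required for a low number, since trifluoromethyl, which has none, gives an at least 4.6-fold lower number from compound 3 to compound 4 (0.66 log units; beyond the scatter). Substitution on the benzyl group now has two examples that lower the number, with trifluoromethyl giving an at least 39-fold lower number from compound 2 to compound 4 (1.59 log units; beyond the scatter) alongside methylsulfonyl's an 8.7-fold lower number from compound 2 to compound 3 (0.94 log units; beyond the scatter), and the 2-(trifluoromethyl)benzyl group replacing phenylcarbamoyl on the ring nitrogen gives an at least 300-fold lower number from compound 1 to compound 4 (2.47 log units; beyond the scatter).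

On these data alone, with compound 4 at a limit, the full size of these steps stays unknown, and so does how far trifluoromethyl outdoes methylsulfonyl. Also open, as far as these compounds go, is whether the low number needs a group of this heavy-atom count, as a methyl group, a chlorine atom, a nitrile, an amine or a carboxylic acid on the same aromatic carbon would show, and whether trifluoromethyl would do the same on another carbon of that ring.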